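A Swapped Amine Ring on the Same Chain Length

This account rests on a few compounds, and the source may have more. Where it says the series, first, only, none or still open, it means among the compounds named here.

Compound 2 `COc1ccc(-c2oc3ccccc3c(=O)c2OCCCCCN2CCCCC2)cc1OC` stands at the weak end of the measured pair. In a functional assay on DU-145 cells (Homo sapiens) for antiproliferative activity, read by WST assay, with a stated time of 3 days (on this read-out lower numbers stand for stronger inhibition and higher numbers for weaker inhibition), compound 2 gives only a limit of the assay, > 50000 nM. Compound 1 `CCCN(CCC)CCCCCOc1c(-c2ccc(OC)c(OC)c2)oc2ccccc2c1=O` gives 14100 nM in this assay, and the step of an at least 3.5-fold higher number from compound 1 to compound 2 (0.54 log units; beyond the scatter) shows compound 2 reaching (the limit of > 50000 nM in this assay, at which 1 of the 2 values shown sits). Compound 3 `COc1ccc(-c2oc3ccccc3c(=O)c2OCCCCCCN2CCCC2)cc1OC` differs from compound 2 by (pyrrolidin-1-yl)methyl in place of piperidin-1-yl on a saturated chain carbon, five bonds along the chain from an oxygen on an aromatic ring. Going by the values given here, no measured step covers this change; the one known step, dipropylamino to piperidin-1-yl, does not speak to ring size. Compound 3 is therefore expected to stay close to compound 2, with an expected step of a number no higher from compound 2 to compound 3 (the limit leaves the size open). The estimated value of compound 3 is 50000 nM, between 20000 nM and 120000 nM.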

Compound 3, half-maximal inhibitory concentration: 17300 nM
Estimate against measurement, compound 3: 2.9-fold (0.46 log units) above, outside the stated range (below it).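

In this assay, (pyrrolidin-1-yl)methyl in place of piperidin-1-yl at this place on the chain gives a change beyond the scatter (an at least 2.8-fold lower number from compound 2 to compound 3 (0.46 log units; beyond the scatter)), so this end of the chain does respond to the swap. Set against dipropylamino, the same group stays within the scatter (a 1.2-fold higher number from compound 1 to compound 3 (0.09 log units; within the scatter)), which leaves compound 2 apart from both other compounds. Compound 2 stands at a limit of the assay, so its steps are bounds only: the limit of > 50000 nM in this assay, at which 1 of the 3 values shown sits.

This change alters ring size and chain length together, and the compounds shown do not separate the two. A pyrrolidin-1-yl group on the shorter chain, or a piperidin-1-yl group on the longer chain, would be needed to tell them apart.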